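The source may hold more compounds than are shown below. What is called first, only, known or untested is meant among the compounds shown, and "the series" means these compounds.

Compound 1 `CC(=O)OCCO[C@H](CC=C(C)C)C1=CC(=O)c2c(O)ccc(O)c2C1=O`: 15500 nM
Compound 2 `CC(C)=CC[C@@H](OC(=O)C1CCCO1)C1=CC(=O)c2c(O)ccc(O)c2C1=O`: 10500 nM

Both compounds share one core and differ only in the group on the oxygen on a saturated carbon. In a functional assay on DU-145 cells (Homo sapiens) for cytotoxicity, read by MTT assay (a lower number here means a stronger inhibitor, a higher number a weaker inhibitor), compound 1 gives 15500 nM, and compound 2 gives 10500 nM. Compound 2 sits together with compound 1 on these numbers: the step of a 1.5-fold lower number from compound 1 to compound 2 (0.17 log units; within the scatter) shows no difference beyond the scatter of this assay.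

Compound 3 `CCC(O)CO[C@H](CC=C(C)C)C1=CC(=O)c2c(O)ccc(O)c2C1=O` has not yet been measured. It differs from compound 2 in this way: 2-hydroxybutyl in place of (oxolan-2-yl)carbonyl on an oxygen on a saturated carbon. Among the measured compounds shown here, the only step that bears on this change is a 1.5-fold lower number from compound 1 to compound 2 (0.17 log units; within the scatter), which swapped one group at the same oxygen without moving the number beyond the scatter. On that basis the next swap at the same place is expected to leave the number about where compound 2 stands, with no step beyond the scatter in either direction.

Compound 3 is therefore estimated at 13000 nM, with a range from 5000 nM to 35000 nM. This corresponds to an expected step of a 1.2-fold higher number from compound 2 to compound 3 (0.09 log units; within the scatter).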

Compound 3, half-maximal inhibitory concentration: 16400 nM
The estimate for compound 3 lay 1.3-fold (0.10 log units) below the measured number; the measured number falls inside the stated range.
By their numbers in this assay, from the lowest: compounds 2, 1 and 3 (each within the scatter of the next).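

In this assay, the change to compound 3 puts 2-hydroxybutyl, an open chain with a hydrogen-bond donor, in place of (oxolan-2-yl)carbonyl, which has a five-membered non-aromatic ring and no such donor (a 1.6-fold higher number from compound 2 to compound 3 (0.19 log units; within the scatter)). Even this exchange of a ring for a hydroxyl-bearing chain leaves the number within the scatter, and so does the comparison with the acetoxy-bearing group of compound 1 (a 1.1-fold higher number from compound 1 to compound 3 (0.02 log units; within the scatter)). All three groups on this oxygen therefore give numbers that cannot be told apart, and nothing measured here explains that result.

As far as these compounds go, it remains open whether an amine, a carboxylic acid or a much longer chain on this oxygen would move the number beyond the scatter. These three compounds also cannot show how much the group on this oxygen contributes compared with the shared core.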